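Thioether in place of ether on the shared core

The source may hold more compounds than are shown below. What is called first, only, known or untested is meant among the compounds shown, and "the series" means these compounds.

Compound 1 `Nc1cc(N)c2nc(-c3ccccc3)c(Oc3ccc(F)cc3)nc2c1` is the reference point of this small set. Within the data shown here, in a functional assay on COLO 205 cells (Homo sapiens) for inhibition, read by sulforhodamine B assay, with a stated time of 48 h (on this read-out lower numbers stand for stronger inhibition of growth and higher numbers for weaker inhibition of growth), compound 1 gives 36300 nM, the only number among the three values recorded. Compound 2 `COc1cc(CNc2nc3cc(N)cc(N)c3nc2-c2ccccc2)cc(OC)c1OC` gives < 50200 nM in this assay, which is a limit and not a number. Compound 3 `COc1ccc(CNc2nc3cc(N)cc(N)c3nc2-c2ccccc2)cc1OC` gives < 100000 nM in this assay, also a limit. Among the measured compounds shown here, the single one-place comparison within the set, a step that the two limits leave unreadable from compound 2 to compound 3, therefore carries no readable size.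

Compound 4 `COc1ccc(Sc2nc3cc(N)cc(N)c3nc2-c2ccccc2)cc1` differs from compound 1 in one place: (4-methoxyphenyl)sulfanyl in place of 4-fluorophenoxy on an aromatic carbon. For the measured compounds named here, no measured step touches this position or this kind of exchange; the one step between measured compounds concerns a methoxy on a different ring and is unreadable from its two limits. There is thus no measured basis for expecting a shift beyond the usual scatter in this assay in either direction.

Compound 4 is accordingly estimated at 36000 nM in this assay, with a range from 12000 nM to 100000 nM, which means an expected step of a 1.0-fold lower number from compound 1 to compound 4 (0.00 log units; within the scatter).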

Compound 4, concentration for total growth inhibition: < 100000 nM
Compound 4 gave a limit, no number (the forecaster's own chance of this, stated with the estimate: 30%); the middle value lies beyond the limit too.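

In this assay compound 4 gives < 100000 nM, which is a limit and not a number, so the step from compound 1 to compound 4 cannot be read. The compounds shown leave open how far (4-methoxyphenyl)sulfanyl in place of 4-fluorophenoxy on the shared core moves growth inhibition, and in which direction.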